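Benzyl replaces 2-methoxyphenyl on the aromatic nitrogen

The source may report more compounds than this note shows. Statements on the series, on what has been measured and on what is new or still open speak of the compounds shown alone.

For the measured compounds named here, in a functional assay on SW-620 cells (Homo sapiens) for antiproliferative activity, read by MTT assay, with a stated time of 48 h (on this read-out lower numbers stand for an effect already at smaller amounts and higher numbers for an effect only at larger amounts of compound), compound 2 (`COc1ccccc1-n1c(SCC(=O)Nc2nc3ccc(C)cc3s2)nc2c(c1=O)SCC2`) gives 230 nM as the lower of the two numbers so far, while compound 1 (`Cc1ccc2nc(NC(=O)CSc3nc4c(c(=O)n3-c3ccc(F)cc3)SCC4)sc2c1`) gives 8620 nM on the same read-out. Compound 3 (`Cc1ccc2nc(NC(=O)CSc3nc4c(c(=O)n3Cc3ccccc3)SCC4)sc2c1`) keeps the shared core and carries benzyl in place of 2-methoxyphenyl on an aromatic nitrogen. Going by the values given here, only one measured step bears on this place: a 37-fold lower number from compound 1 to compound 2 (1.57 log units; beyond the scatter) with 2-methoxyphenyl in place of 4-fluorophenyl, and that step is large. It shows that a swap here can move the number strongly, but it does not tell how benzyl will behave. With compound 2 at the low end so far, a moderate move toward a higher number in this assay is expected. The expected change is a 5.7-fold higher number from compound 2 to compound 3 (0.75 log units; beyond the scatter) on this estimate. Compound 3 is therefore expected at 1300 nM within a range from 250 nM to 7000 nM on this estimate.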

Compound 3, half-maximal effective concentration: 8520 nM
Estimate against measurement, compound 3: 6.6-fold (0.82 log units) below; the whole stated range lies below it.
By their numbers in this assay, from the lowest: compound 2; then compounds 3 and 1 (each within the scatter of the next).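

In this assay the change to benzyl gives a 37-fold higher number from compound 2 to compound 3 (1.57 log units; beyond the scatter) and so removes the low number of compound 2, which shows that this place on the aromatic nitrogen responds strongly to a change in either direction. The other new step, a 1.0-fold lower number from compound 1 to compound 3 (0.01 log units; within the scatter), lies within the scatter, so 4-fluorophenyl and benzyl cannot be told apart here, and of the three groups only 2-methoxyphenyl stands apart. Nothing measured here explains why this one group behaves differently.

Still open, as far as these compounds go, is whether 4-methoxyphenyl or 2-methoxybenzyl would share the low number of compound 2, or whether only the exact 2-methoxyphenyl group gives it. Also open, from the compounds shown here alone, is how a longer chain, such as phenethyl, would behave at this place.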